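Lengthening an ester chain in two related cores

A few compounds are considered here, and "the series" means these few. Any claim that something is new, unique, unknown or untested is made for them only; others in the source may bear on it.

Of the compounds shown here, three sharing most of their structure have been measured in a functional assay on A549 cells (Homo sapiens) for cytotoxicity, read by MTT assay, with a stated time of 72 h; on this read-out lower numbers stand for stronger inhibition and higher numbers for weaker inhibition: compound 3 `COC(=O)c1sc2ccccc2c1Nc1cc(OC)c(OC)c(OC)c1`, compound 1 `CCOC(=O)c1sc2ccccc2c1Nc1cc(OC)c(OC)c(OC)c1` and compound 2 `COC(=O)c1sc2ncccc2c1Nc1cc(OC)c(OC)c(OC)c1`. Compound 3 gives 2850 nM, compound 1 gives 8530 nM, and compound 2 gives 3850 nM. Compound 1 differs from compound 3 in a single spot, (methyl in place of hydrogen on a saturated chain carbon bound to an oxygen next to a carbonyl group), and this change made the step of a 3.0-fold higher number from compound 3 to compound 1 (0.48 log units; beyond the scatter), a weakening of inhibition. Compound 2 carries a different core from compound 3; the difference between the two cores is not broken down here. Compound 4 `CCOC(=O)c1sc2ncccc2c1Nc1cc(OC)c(OC)c(OC)c1` has not yet been measured. It stands to compound 2 exactly as compound 1 stands to compound 3: methyl in place of hydrogen on a saturated chain carbon bound to an oxygen next to a carbonyl group, the same change at the same place, made this time on the core of compound 2. In this assay the step is expected to be a 3.0-fold higher number from compound 2 to compound 4 (0.48 log units; beyond the scatter), because the identical change on the other core gave a 3.0-fold higher number from compound 3 to compound 1 (0.48 log units; beyond the scatter), and nothing measured here suggests the core alters that. Compound 4 is therefore estimated at 11500 nM, with a likely range from 5000 nM to 26000 nM.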

Compound 4, half-maximal inhibitory concentration: 7160 nM
For compound 4 the middle estimate is 1.6-fold (0.21 log units) above the measured one; measured number inside the range.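

In this assay, placing a methyl on the saturated chain carbon bound to an oxygen next to a carbonyl group, which turns methoxycarbonyl into ethoxycarbonyl, gives a 1.9-fold higher number from compound 2 to compound 4 (0.27 log units; within the scatter). Set beside the earlier step, this result gives no sign that the two cores respond differently: the same change on two cores in this assay, a 3.0-fold higher number (0.48 log units; beyond the scatter) from compound 3 to compound 1 and a 1.9-fold higher number (0.27 log units; within the scatter) from compound 2 to compound 4, 1.6-fold (0.21 log units) apart, within the scatter of two such steps. Among the compounds shown here, the change therefore appears to carry across these two cores, but each core supplies only one pair of compounds, and the step on the core of compound 2 cannot by itself be separated from ordinary measurement scatter, so this does not establish a true effect on that core or predict the outcome on any other core.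

The compounds shown leave open how a longer chain, such as propyl or butyl, would read in place of the ethyl of the ester on either core. They also leave open what would happen if the ester gave way to a carboxylic acid or an amide.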